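Shrinking the Amide: From Compound 1 to Compound 4

This account rests on a few compounds, and the source may have more. Where it says the series, first, only, none or still open, it means among the compounds named here.

Compound 1 `N#C[C@@H]1CCCN1C(=O)[C@@H]1C[C@H](C(=O)N2CCOCC2)CN1`: 73%
Compound 2 `N#C[C@@H]1CCCN1C(=O)[C@@H]1C[C@H](CO)CN1`: 64%
Compound 3 `N#C[C@@H]1CCCN1C(=O)[C@@H]1C[C@H](C(=O)N2CCCCC2)CN1`: 84%

These three compounds were tested in an assay on the whole organism (plasma, strain Sprague-Dawley) for inhibition of Dipeptidyl peptidase 4 (Rattus norvegicus), with a stated time of 6 h, at a dose of 1 mg/kg by the oral route; on this read-out higher numbers stand for more inhibition at the one dose given (going by the name of the read-out) and lower numbers for less inhibition. Compound 1 stands second highest of the three numbers; compound 2 lies within the scatter of it, while compound 3 is higher, a number 11 percentage points higher from compound 1 to compound 3 (beyond the scatter). Compound 4 `CNC(=O)[C@@H]1CN[C@H](C(=O)N2CCC[C@H]2C#N)C1` differs from compound 1 by methylamino in place of morpholin-4-yl on a carbonyl carbon. For the measured compounds named here, the only measured step at this carbonyl, a number 11 percentage points higher from compound 1 to compound 3 (beyond the scatter), swapped one six-membered ring for another and gave a modest rise; no measured step replaces the ring with a small open chain. Compound 2, the smallest compound, sits within the scatter of compound 1, so a small group need not cost much. Compound 4 is therefore expected near 65%, within 48% to 80%, a step of a number 8 percentage points lower from compound 1 to compound 4 (within the scatter) expected to stay within the scatter.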

Compound 4, a percentage reported as inhibition, in the whole organism at one dose (the size of the read-out at that dose, not a potency): 75%
Compound 4: middle estimate off by 10 percentage points, on the low side; the range from low to high includes it.
By their numbers in this assay, from the lowest: compounds 2, 1, 4 and 3 (each within the scatter of the next, the first and the last beyond it).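

Replacing the ring on this carbonyl carbon with the open methylamino chain costs no clear inhibition: the change gives a number 2 percentage points higher from compound 1 to compound 4 (within the scatter) and a number 9 percentage points lower from compound 3 to compound 4 (within the scatter). Among compounds 1, 3 and 4, then, a ring at this place is not required for inhibition at this one dose. The amide also separates itself from the hydroxymethyl group on the saturated ring carbon, with methylcarbamoyl giving a number 11 percentage points higher from compound 2 to compound 4 (beyond the scatter).

No measurement here explains these numbers. Open, from the compounds shown here alone, is how a longer chain such as butylamino, or a carboxylic acid in place of the amide, would read.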